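A few compounds are considered here, and "the series" means these few. Any claim that something is new, unique, unknown or untested is made for them only; others in the source may bear on it.

Measured so far in a functional assay on the whole organism (Tail, strain ICR) with Mus musculus as the target, in the tail flick test, with a stated time of 120 min, at a dose of 25 umol/kg by the oral route; a lower number here means a weaker effect, a higher number a stronger effect of the compound at the dose given:
- compound 1 `CC[C@H](C)[C@H](NC(=O)CN(c1nc(Cl)nc2[nH]cnc12)C1CC1)C(=O)OCc1ccccc1`: 22%
- compound 2 `O=C(O)C[C@H](NC(=O)CN(c1nc(Cl)nc2[nH]cnc12)C1CC1)C(=O)O`: 22%
- compound 3 `NC(=O)CC[C@H](NC(=O)CN(c1nc(Cl)nc2[nH]cnc12)C1CC1)C(=O)O`: 17.8%

Compound 1 stands level with compound 2 at the digits shown, and the two together give the highest numbers of the three, while compound 3 lies within the scatter of both. Compound 4 `NC(=O)C[C@H](NC(=O)CN(c1nc(Cl)nc2[nH]cnc12)C1CC1)C(=O)OCc1ccccc1` differs from compound 1 by carbamoylmethyl in place of sec-butyl on a saturated chain carbon bound to an amide-type nitrogen and a carbonyl carbon. Going by the values given here, no measured step repeats this exact exchange. Among the compounds with values here, the one step available, a number 4.2 percentage points lower from compound 2 to compound 3 (within the scatter), brings in the same carbamoylmethyl group and was within the scatter, and all three measured values of this assay sit close together. The expected step of a number 2 percentage points lower from compound 1 to compound 4 (within the scatter) is therefore none beyond the scatter. Compound 4 is estimated at 20%, in the range 8% to 32%.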

Compound 4, a percentage reported as activity, at one dose (the size of the read-out at that dose, not a potency): 15.1%
Compound 4: the middle estimate sits 4.9 percentage points above what was measured; the measured number falls inside the stated range.
By their numbers in this assay, from the lowest: compounds 4, 3, 1 and 2 (each within the scatter of the next).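

In this assay, putting carbamoylmethyl in place of sec-butyl on this chain carbon, with the rest of the molecule unchanged, gives a number 6.9 percentage points lower from compound 1 to compound 4 (within the scatter). Going by these compounds alone, this is the first direct comparison at this position of an all-carbon side chain with one carrying a hydrogen-bond donor and acceptor, and the read-out does not separate them. Nothing shown explains this result.

On these data alone, whether an aminobutyl chain or a hydroxymethyl group on this carbon would move the number beyond the scatter remains open.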